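A Fluorinated Ring Replaces Oxane in Compound 3

The source may hold more compounds than are shown below. What is called first, only, known or untested is meant among the compounds shown, and "the series" means these compounds.

Going by the values given here, in a physicochemical assay for solubility, using the shake flask method, in phosphate buffer, measured as kinetic solubility, with a stated time of 20 h, at pH 6.5 (on this read-out lower numbers stand for lower solubility and higher numbers for higher solubility), compound 3 (`FC(F)(F)c1ccc(Nc2cc3[nH]c(C4CCOCC4)nc3cn2)nc1`) gives 155000 nM as the only true number among the values so far. Compound 1 (`FC(F)(F)c1cccc(-c2nc3cnc(Nc4cnccn4)cc3[nH]2)c1`) reports < 5000 nM as a limit of the assay. Compound 2 (`FC(F)(F)c1cccc(-c2nc3cnc(Nc4cccnn4)cc3[nH]2)c1`) likewise reports < 5000 nM as a limit. Among the compounds with values here, no size can be read from the step that the two limits leave unreadable from compound 1 to compound 2 and no measured step covers the swap at hand. Compound 4 (`FC1(F)CCC(c2nc3cnc(Nc4ccc(C(F)(F)F)cn4)cc3[nH]2)CC1`) differs from compound 3 in one place: 4,4-difluorocyclohexyl in place of oxan-4-yl on an aromatic carbon on an aromatic carbon between two ring nitrogen atoms. Compound 1 and compound 2 lack oxan-4-yl and stand at the limit of < 5000 nM in this assay, at which 2 of the 3 values shown sit, which gives only loose support for expecting a fall. The expected change is a 6.2-fold lower number from compound 3 to compound 4 (0.79 log units; beyond the scatter) and it is a fall beyond the scatter. The estimate for compound 4 is 25000 nM with 5000 nM to 90000 nM as its expected range.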

Compound 4, solubility: 99000 nM
Estimate against measurement, compound 4: 4.0-fold (0.60 log units) below; the whole stated range lies below it.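

In this assay, putting 4,4-difluorocyclohexyl in place of oxan-4-yl gives a 1.6-fold lower number from compound 3 to compound 4 (0.19 log units; within the scatter), so the two compounds cannot be told apart. Unlike the earlier step between two limits, which cannot be read, this is a readable step at this position, and it shows that the ring oxygen of oxan-4-yl can give way to a carbon-only ring carrying two fluorine atoms with no difference beyond the scatter. No measured property shown here accounts for this result. From the compounds shown here alone, how an amine or a carboxylic acid in this place would read in this assay remains open.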